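This account rests on a few compounds, and the source may have more. Where it says the series, first, only, none or still open, it means among the compounds named here.

Compound 1 `COc1cc(-c2nccn2C(C)C)cc(OC)c1OC`: "not determined" (no result reported)
Compound 2 `COc1cc(-c2nccn2S(=O)(=O)c2ccc(C)cc2)cc(OC)c1OC`: "not determined" (no result reported)
Compound 3 `COc1cc(-c2nccn2-c2ccc3cc[nH]c3c2)cc(OC)c1OC`: 40000 nM

In an ADME assay on HUVEC cells (Homo sapiens) for cytotoxicity, read by MTT assay, with a stated time of 72 h (on this read-out higher numbers stand for weaker inhibition and lower numbers for stronger inhibition), compound 1 gives "not determined" (no result reported), so it offers no number to start from. Compound 2 is in the same position, with "not determined" (no result reported). Only compound 3 gives a number, 40000 nM.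

The next compound to be tested is compound 4 `COc1cc(-c2nccn2-c2cccc(C)c2)cc(OC)c1OC`. It keeps the core of compound 1, but has 3-methylphenyl in place of isopropyl on an aromatic nitrogen.

With no number for compound 1, the size and direction of this step in this assay cannot be read from the data. The expectation must lean on a single measurement instead. Like compound 4, compound 3 carries an aromatic ring system on that nitrogen, and it gives 40000 nM. Compound 4 is therefore expected to differ from that level by no more than the usual scatter, though one value is thin support.

For compound 4 the estimated value is 30000 nM, with an expected range from 6000 nM to 100000 nM.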

Compound 4, half-maximal inhibitory concentration: > 100000 nM
Compound 4: a limit, no number; the forecaster's own chance of this, stated with the estimate: 25%; middle value at least 3.3-fold (0.52 log units) from the limit.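

In this assay compound 4 gives > 100000 nM, which is a limit and not a number. Going by these compounds alone, compound 1 has no single number, so no step between compound 1 and compound 4 can be read. The compounds shown leave open how much 3-methylphenyl in place of isopropyl changes the result in this assay.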